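Benzyl Ester Replaces Trichloroethyl at a Half-Life Limit

A few compounds are considered here, and "the series" means these few. Any claim that something is new, unique, unknown or untested is made for them only; others in the source may bear on it.

Compound 1 `CCOc1cc(NC(=O)C2(NC(=O)c3ccc4c(C5CCCC5)c(-c5ncc(Cl)cn5)n(C)c4c3)CCC2)ccc1/C=C/C(=O)OCOP(=O)(O)O`: in an ADME assay (liver) for pharmacokinetics, with Liver microsome (Homo sapiens) as the target, using microsomes (on this read-out higher numbers stand for a longer-lived compound and lower numbers for a shorter-lived compound), compound 1 gives 0.167 h.
Compound 2 `CCOc1cc(NC(=O)C2(NC(=O)c3ccc4c(C5CCCC5)c(-c5ncc(Cl)cn5)n(C)c4c3)CCC2)ccc1/C=C/C(=O)OCC(C)C`: in this assay compound 2 gives > 5 h, which is a limit of the assay and not a number.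
Compound 3 `CCOc1cc(NC(=O)C2(NC(=O)c3ccc4c(C5CCCC5)c(-c5ncc(Cl)cn5)n(C)c4c3)CCC2)ccc1/C=C/C(=O)OCC(Cl)(Cl)Cl`: in this assay compound 3 gives > 5 h, again a limit and not a number.

Compound 3 therefore stands at the top of what the assay can report, at the limit of > 5 h in this assay, at which 2 of the 3 values shown sit. Compound 4 `CCOc1cc(NC(=O)C2(NC(=O)c3ccc4c(C5CCCC5)c(-c5ncc(Cl)cn5)n(C)c4c3)CCC2)ccc1/C=C/C(=O)OCc1ccccc1` differs from it in one place: phenyl in place of trichloromethyl on a saturated chain carbon bound to an oxygen next to a carbonyl group. Going by the values given here, two measured steps bear on this kind of change. Both an at least 29-fold higher number from compound 1 to compound 2 (1.47 log units; beyond the scatter) and an at least 29-fold higher number from compound 1 to compound 3 (1.47 log units; beyond the scatter) show that swapping the phosphorus-bearing group for a carbon group on that chain carbon lifts the number up to the limit. Between the two carbon groups themselves, a step that the two limits leave unreadable from compound 2 to compound 3 cannot be read, as both sit at the limit. Compound 4 keeps a carbon group in the same place, so the expected step of an at least 1.2-fold lower number from compound 3 to compound 4 (0.09 log units; that floor lies within the scatter) is not one that can be read against the limit. Compound 4 is estimated at 4 h, with a range from 1.5 h to 8 h.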

Compound 4, half-life: > 5 h
Compound 4: no number, only a limit; the forecaster's own chance of this, stated with the estimate: 50%; middle value at least 1.2-fold (0.09 log units) from the limit.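

Compound 4 shows that a six-membered aromatic ring of carbon only, and not just an open-chain carbon group, can sit on this saturated chain carbon and still reach the top of what this assay can report: the limit of > 5 h in this assay, at which 3 of the 4 values shown sit.

Replacing the phosphorus-bearing group with phenyl gives an at least 29-fold higher number from compound 1 to compound 4 (1.47 log units; beyond the scatter), so the large rise now holds for three different carbon groups: isopropyl, trichloromethyl and phenyl. The steps among compound 2, compound 3 and compound 4 cannot be read, as all three values are limits and not numbers.

On these data alone, how long each of these three esters really lasts therefore stays open, and so does any order among them. Also open, as far as these compounds go, is whether an amine or a carboxylic acid on this chain carbon would stay at the limit or come closer to compound 1. Compound 1 gives 0.167 h.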